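Swapping a Piperazinylmethyl Amide Chain for Propanoyl: Cytotoxicity Outlook

The compounds below may be only part of what the source reports. "The series", "measured", "known", "first", "only" and "open" are said of these compounds alone.

Compound 1 `CN1CCN(CC(=O)Nc2ccc(-c3nc4cc(C(F)(F)F)ccc4n3C)cc2)CC1`: 16000 nM
Compound 2 `Fc1cccc(F)c1-c1nc2cc(C(F)(F)F)ccc2[nH]1`: >= 100000 nM

Two compounds of this set have been examined in an ADME assay on BHK cells (Mesocricetus auratus) for cytotoxicity, read by MTT assay, with a stated time of 96 h; on this read-out higher numbers stand for lower toxicity in this test and lower numbers for higher toxicity in this test. In this assay compound 1 gives 16000 nM, which is the only plain number among the results shown. For compound 2 the assay reports only a limit, >= 100000 nM, a value sitting at the limit of >= 100000 nM in this assay, at which 1 of the 2 values shown sits. Compound 3 `CCC(=O)Nc1ccc(-c2nc3cc(C(F)(F)F)ccc3n2C)cc1` differs from compound 1 in a single place: methyl in place of 4-methylpiperazin-1-yl on a saturated chain carbon bound to a carbonyl carbon. Among the compounds with values here, no step between two measured compounds is available to gauge a change of this kind, so the size of the move from compound 1 to compound 3 cannot be read from the data. Compound 3 is expected to show a modest step toward lower toxicity, a 2.5-fold higher number from compound 1 to compound 3 (0.40 log units; beyond the scatter), one that may well stay within the usual scatter. The estimate for compound 3 is 40000 nM, with a range from 10000 nM to 150000 nM.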

Compound 3, half-maximal cytotoxic concentration: > 100000 nM
Compound 3 was reported as a limit; the forecaster's own chance of this, stated with the estimate: 30%; at least 2.5-fold (0.39 log units) between middle value and limit.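

At the saturated chain carbon bound to a carbonyl carbon, the data now hold a first measured change: with methyl in place of 4-methylpiperazin-1-yl, this assay shows an at least 6.2-fold higher number from compound 1 to compound 3 (0.79 log units; beyond the scatter). Compound 3 gives > 100000 nM, which is a limit and not a number: the limit of > 100000 nM in this assay, at which 1 of the 3 values shown sits.

The step therefore shows that removing the 4-methylpiperazin-1-yl group from this position moves the read-out toward lower toxicity in this test, by more than the usual scatter. As far as these compounds go, how far compound 3 lies past its limit remains open, as does whether the whole ring or only its nitrogen atoms account for the step. Nor does this single change tell how a dimethylamino group, a carboxylic acid or a longer alkyl chain on the same carbon would read in this assay.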